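Bromo to iodo: extending the halogen step

The source may report more compounds than this note shows. Statements on the series, on what has been measured and on what is new or still open speak of the compounds shown alone.

Compound 3 `O=C(c1ccccc1)c1cccc(NS(=O)(=O)c2ccc(Br)cc2)c1` stands highest of the three numbers in an assay on CHO cells for binding affinity to integrin alpha-1 (Homo sapiens), read by WST assay, with a stated time of 2 h, tested at 50 uM (a lower number here means less inhibition, a higher number more inhibition at the concentration tested (going by the name of the read-out)), where compound 3 gives 92%. Compound 1 `O=C(c1ccccc1)c1cccc(NS(=O)(=O)c2ccccc2)c1` gives 4% and compound 2 `Cc1ccc(S(=O)(=O)Nc2cccc(C(=O)c3ccccc3)c2)cc1` gives 34%. The steps of a number 30 percentage points higher from compound 1 to compound 2 (beyond the scatter) and a number 88 percentage points higher from compound 1 to compound 3 (beyond the scatter) show that a substituent on this aromatic carbon raises inhibition, and a number 58 percentage points higher from compound 2 to compound 3 (beyond the scatter) shows bromo well beyond methyl. Compound 4 `O=C(c1ccccc1)c1cccc(NS(=O)(=O)c2ccc(I)cc2)c1` carries iodo in place of bromo on an aromatic carbon. Among the compounds with values here, no measured step exchanges one halogen for another, and compound 3 already sits near the top of the scale, so the room upward is small; iodo is expected to hold the level of bromo. The expected step is a number 2 percentage points lower from compound 3 to compound 4 (within the scatter), within the scatter. Compound 4 is estimated at 90%, between 75% and 98%.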

Compound 4, a percentage reported as inhibition, at one concentration (the size of the read-out at that concentration, not a potency): 72%
For compound 4 the middle estimate is 18 percentage points above the measured one, and the stated range ends above it.
By their numbers in this assay, from the lowest: compound 1; then compound 2; then compound 4; then compound 3.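

In this assay the two halogens at this position do not read alike, with a number 20 percentage points lower from compound 3 to compound 4 (beyond the scatter) as the first step measured between halogens. Iodo still stands well clear of hydrogen and methyl, with a number 68 percentage points higher from compound 1 to compound 4 (beyond the scatter) and a number 38 percentage points higher from compound 2 to compound 4 (beyond the scatter), so the order hydrogen, methyl, iodo, bromo holds for these four compounds only. Nothing available accounts for the gap between iodo and bromo.

Open, on these data alone, is where chloro or fluoro on this carbon would fall in that order. Also open, as far as these compounds go, is how an amine or a carboxylic acid would read here.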